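The source may hold more compounds than are shown below. What is called first, only, known or untested is meant among the compounds shown, and "the series" means these compounds.

Measured compounds:
compound 1 `CN(Cc1ccccc1)C(=O)C1CCN(C(=O)c2ccc(S(C)(=O)=O)c([N+](=O)[O-])c2)CC1` gives > 27000 nM in an ADME assay on HepG2 cells (Homo sapiens) for cytotoxicity, read by CellTiter-Glo and ATP content, with a stated time of 72 h; on this read-out higher numbers stand for an effect only at larger amounts of compound and lower numbers for an effect already at smaller amounts; this value is a limit of the assay, not a number.
Compound 2 `CN(Cc1ccccc1F)C(=O)C1CCN(C(=O)c2ccc(S(C)(=O)=O)c([N+](=O)[O-])c2)CC1` gives > 27000 nM in this assay; this too is a limit of the assay, not a number.
Among the measured compounds shown here, compound 3 `CN(CC(=O)N1CCN(c2ccc(F)cc2)CC1)C(=O)c1ccc(S(C)(=O)=O)c([N+](=O)[O-])c1` gives 17200 nM in this assay, the only number among the three.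

Compound 1 and compound 2 share a core and differ in one place: hydrogen in place of fluoro on an aromatic carbon. The step that the two limits leave unreadable from compound 2 to compound 1 cannot be read because the limit of > 27000 nM in this assay, at which 2 of the 3 values shown sit, is where both of these values sit. Compound 3 carries a different core; how its core differs from that of compound 2 is not broken down here.

Compound 4 `CN(CC(=O)N1CCN(c2ccccc2)CC1)C(=O)c1ccc(S(C)(=O)=O)c([N+](=O)[O-])c1` has not yet been measured in this assay. It differs from compound 3 in one place: hydrogen in place of fluoro on an aromatic carbon. This is the same kind of change as that from compound 2 to compound 1, though not the same one: in compound 2 the fluoro sits ortho to a large group, in compound 3 it sits para to a large group.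

For the measured compounds named here, for compound 4 the step of a 1.2-fold higher number from compound 3 to compound 4 (0.07 log units; within the scatter) is expected to be small, since the one measured example of this kind of change, a step that the two limits leave unreadable from compound 2 to compound 1, gave no readable size. Going by the values given here, compound 3 itself sits at 17200 nM, the only number measured among the three. Compound 4 is therefore estimated at 20000 nM, between 9000 nM and 45000 nM, with a fair chance that this assay again reports only a limit.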

Compound 4, half-maximal effective concentration: > 27000 nM
Compound 4: only a limit was reported (the forecaster's own chance of this, stated with the estimate: 35%); middle value at least 1.3-fold (0.13 log units) from the limit.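

In this assay, the change from 4-fluorophenyl to phenyl on the core of compound 3 gives an at least 1.5-fold higher number from compound 3 to compound 4 (0.19 log units; that floor lies within the scatter), so this step has a floor and no upper end. On the core of compound 2, the same kind of change, hydrogen in place of fluoro on an aromatic carbon, cannot be read, and no size can be carried from one core to the other because compound 1, compound 2 and compound 4 all end at one limit of the assay: the limit of > 27000 nM in this assay, at which 3 of the 4 values shown sit. On both cores the compound carrying hydrogen ends at that limit, which is all the two cases share; whether the step is equal on the two cores, or small or large on either, is not shown.

The compounds shown leave open what a chloro, methoxy or trifluoromethyl group, or an amine or carboxylic acid, would give on the phenyl ring of compound 4, and whether any of these would yield a number rather than a limit. Also open, going by these compounds, is what would follow from replacing the nitro group common to all four compounds with, for example, a nitrile.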